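A bromo for trifluoromethyl swap in a small series

This account rests on a few compounds, and the source may have more. Where it says the series, first, only, none or still open, it means among the compounds named here.

Of the compounds shown here, three sharing one core have been measured in a functional assay on A549 cells (Homo sapiens) for inhibition, read by CCK-8 assay, with a stated time of 72 h, tested at 1 uM; a higher number here means more inhibition of growth at the concentration tested, a lower number less inhibition of growth. Compound 1 `CN(C)C(=O)c1cc2cnc(Nc3ccc(NC(=O)C4(C(=O)Nc5ccc(F)cc5)CC4)cc3)nc2n1C1CCCC1`, with a 4-fluorophenyl on the amide-type nitrogen, gives 86.6%. Compound 2 `CN(C)C(=O)c1cc2cnc(Nc3ccc(NC(=O)C4(C(=O)Nc5ccc(Br)cc5)CC4)cc3)nc2n1C1CCCC1`, with a 4-bromophenyl there, gives -6.6%, and compound 3 `CN(C)C(=O)c1cc2cnc(Nc3ccc(NC(=O)C4(C(=O)Nc5cccc(C(F)(F)F)c5)CC4)cc3)nc2n1C1CCCC1`, with a 3-(trifluoromethyl)phenyl, gives 15.7%. Compound 3 is thus second of the three. The step up to it is modest, a number 22.3 percentage points higher from compound 2 to compound 3 (beyond the scatter), while the step down to it is large, a number 70.9 percentage points lower from compound 1 to compound 3 (beyond the scatter).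

Compound 4 `CN(C)C(=O)c1cc2cnc(Nc3ccc(NC(=O)C4(C(=O)Nc5cccc(Br)c5)CC4)cc3)nc2n1C1CCCC1` differs from compound 3 by one group: bromo in place of trifluoromethyl on an aromatic carbon. In words, this is bromo in place of trifluoromethyl on an aromatic carbon, meta to a large group.

For the measured compounds named here, no measured step makes this exact exchange. The closest evidence is a number 93.2 percentage points lower from compound 1 to compound 2 (beyond the scatter), which brought in bromo, though in place of fluoro, and a number 70.9 percentage points lower from compound 1 to compound 3 (beyond the scatter), which left the 4-fluorophenyl. Both replacements ended low, so compound 1 stands alone at the high end. Going by the values given here, a bromo group has so far been seen only in compound 2, at -6.6%, so the expectation stays close to the low pair. The expected outcome is no step beyond the scatter, an estimated a number 3.7 percentage points lower from compound 3 to compound 4 (within the scatter). For compound 4 the estimated value is 12%, with an expected range from -10% to 45%.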

Compound 4, percent growth inhibition at one concentration: 20.2%
Beside the measured number, compound 4's estimate is 8.2 percentage points below it; measured number inside the range.
By their numbers in this assay, from the lowest: compound 2; then compounds 3 and 4 (each within the scatter of the next); then compound 1.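

In this assay, for the compounds shown here, this is the first direct exchange of trifluoromethyl for bromo on an aromatic carbon, meta to a large group, and it gives a number 4.5 percentage points higher from compound 3 to compound 4 (within the scatter), so the two groups cannot be told apart at this place. The change from 4-bromophenyl to 3-bromophenyl gives a number 26.8 percentage points higher from compound 2 to compound 4 (beyond the scatter), a modest step showing that the place of the bromo affects the reading, while the change from 4-fluorophenyl to 3-bromophenyl gives a number 66.4 percentage points lower from compound 1 to compound 4 (beyond the scatter), which leaves compound 1 alone at the high end of these four compounds. Nothing measured here accounts for these steps.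

The compounds shown leave open whether the high reading of compound 1 belongs to the fluoro group itself or to its place on the ring, a question that fluoro on the same aromatic carbon as the bromo of compound 4 would address. They also leave open how a chloro, a methoxy or an amine at that carbon would read beside the bromo and trifluoromethyl groups.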